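Working notes: cytotoxicity step from compound 3 to compound 4

This account rests on a few compounds, and the source may have more. Where it says the series, first, only, none or still open, it means among the compounds named here.

Measured compounds in an ADME assay on HEK293 cells (Homo sapiens) for cytotoxicity, read by MTT assay, with a stated time of 36 h; on this read-out lower numbers stand for stronger inhibition and higher numbers for weaker inhibition:
Compound 1 `O=C(c1ccc2c(c1)OCCO2)C1CCN(Cc2coc(-c3ccc(Br)cc3)n2)CC1` gives > 150 ug/mL, a limit of the assay.
Compound 2 `O=C(c1ccc2c(c1)OCCO2)C1CCN(Cc2coc(-c3ccoc3)n2)CC1` gives > 150 ug/mL, a limit of the assay.
Compound 3 `O=C(c1ccc2c(c1)CCCC2)C1CCN(Cc2coc(-c3ccc(F)cc3)n2)CC1` gives > 150 ug/mL, a limit of the assay.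

Compound 3 therefore stands only at a limit in this assay, as do the two other values shown. Among the measured compounds shown here, the single measured step, a step that the two limits leave unreadable from compound 1 to compound 2, is left unreadable by its two limits. Compound 4 `COc1ccc(C(=O)C2CCN(Cc3coc(-c4ccc(F)cc4)n3)CC2)cc1` differs from compound 3 by 4-methoxyphenyl in place of 1,2,3,4-tetrahydronaphthalen-6-yl on a carbonyl carbon. For the measured compounds named here, no measured step bears directly on this change; the three measured values coincide because of the limit of > 150 ug/mL in this assay, at which 3 of the 3 values shown sit. The expectation is that compound 4 likewise reaches no readable number in this assay, so the step of a number no higher from compound 3 to compound 4 (the limit leaves the size open) is expected to be none beyond the scatter. Compound 4 is estimated at 150 ug/mL, with a range from 100 ug/mL to 300 ug/mL, most probably reported again as a limit.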

Compound 4, half-maximal inhibitory concentration: > 150 ug/mL
Compound 4 was reported as a limit; the forecaster's own chance of this, stated with the estimate: 85%; the middle value sits exactly at the limit.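

In this assay no step can be read from compound 3 to compound 4, because both stand at one limit: the limit of > 150 ug/mL in this assay, at which 4 of the 4 values shown sit.
The compounds shown leave open where the actual half-maximal inhibitory concentration of any of them lies, and so whether 4-methoxyphenyl in place of 1,2,3,4-tetrahydronaphthalen-6-yl shifts it at all.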